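The compounds below may be only part of what the source reports. "The series", "measured", "known", "first", "only" and "open" are said of these compounds alone.

Compound 2 `COc1cc2ncnc(Nc3cccc(C)c3)c2cc1OCCCCC(=O)Nc1ccc(S(N)(=O)=O)cc1` gives 32100 nM in a functional assay on NCI-H1975 cells (Homo sapiens) for antiproliferative activity, read by MTT assay, with a stated time of 72 h; a lower number here means a stronger inhibitor, a higher number a weaker inhibitor. Compound 1 `COc1cc2ncnc(Nc3cccc(Cl)c3)c2cc1OCCCCC(=O)Nc1ccc(S(N)(=O)=O)cc1` gives 33200 nM in this assay, and the two numbers sit within the scatter of each other, so compound 2 stands level with compound 1 rather than apart from it. Compound 3 `COc1cc2ncnc(Nc3cc(F)c(F)c(F)c3)c2cc1OCCCCC(=O)Nc1ccc(S(N)(=O)=O)cc1` differs from compound 2 by 3,4,5-trifluorophenyl in place of 3-methylphenyl on a nitrogen on an aromatic ring. Among the measured compounds shown here, only one measured step bears on this change, a 1.0-fold lower number from compound 1 to compound 2 (0.01 log units; within the scatter), and it stayed within the scatter. Because that step a 1.0-fold lower number from compound 1 to compound 2 (0.01 log units; within the scatter) left the number unchanged, no shift beyond the scatter is expected for compound 3, with a 1.1-fold lower number from compound 2 to compound 3 (0.03 log units; within the scatter). Compound 3 is therefore estimated at 30000 nM, in a range from 10000 nM to 90000 nM.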

Compound 3, half-maximal inhibitory concentration: 20000 nM
Estimate against measurement, compound 3: 1.5-fold (0.18 log units) above, and the stated range covers the measured number.
By their numbers in this assay, from the lowest: compounds 3, 2 and 1 (each within the scatter of the next).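

The result widens what the chloro-to-methyl exchange showed: on this nitrogen on an aromatic ring, even 3,4,5-trifluorophenyl, with its three fluorines, stays level in this assay (a 1.6-fold lower number from compound 2 to compound 3 (0.21 log units; within the scatter)) and (a 1.7-fold lower number from compound 1 to compound 3 (0.22 log units; within the scatter)). The three aryl groups shown therefore cannot be told apart in this assay, and all three compounds remain weak together. No evidence bears on why this position tolerates the change. From the compounds shown here alone, whether a ring carrying an amine or a carboxylic acid would move the number beyond the scatter stays open, as does the effect of a longer chain on the shared core.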